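The compounds below may be only part of what the source reports. "The series", "measured", "known", "first", "only" and "open" are said of these compounds alone.

In a functional assay on LoVo cells (Homo sapiens) for inhibition, read by colorimetric assay and MTT assay, with a stated time of 72 h (on this read-out higher numbers stand for weaker inhibition and lower numbers for stronger inhibition), compound 1 `C=CCCCCOc1ccccc1-c1cnc(OCCCCC=C)n1C` gives 5000 nM, compound 2 `C#CCCCCOc1ncc(-c2ccccc2OC)n1C` gives 11000 nM and compound 3 `C=CCCCCOc1ncc(-c2ccccc2OC)n1C` gives 4000 nM. Compound 3 therefore stands level with compound 1, as shown by a 1.3-fold lower number from compound 1 to compound 3 (0.10 log units; within the scatter), but clear of compound 2, as shown by a 2.8-fold lower number from compound 2 to compound 3 (0.44 log units; beyond the scatter). Compound 4 `C=CCCCCOc1ncc(-c2cc(Cl)ccc2OC)n1C` carries one change, chloro in place of hydrogen on an aromatic carbon, para to a methoxy group. Neither measured step touches that ring, since both alter chains, so neither gives a direct size for this change. The larger is only modest, so no shift beyond the scatter is expected in this assay. The estimated step is a 1.3-fold lower number from compound 3 to compound 4 (0.12 log units; within the scatter). For compound 4 the estimated value is 3000 nM, with an expected range from 1200 nM to 7000 nM.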

Compound 4, half-maximal inhibitory concentration: 28000 nM
Beside the measured number, compound 4's estimate is 9.3-fold (0.97 log units) below it, and the stated range ends below it.
By their numbers in this assay, from the lowest: compounds 3 and 1 (each within the scatter of the next); then compound 2; then compound 4.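

Chloro in place of hydrogen on the aromatic carbon para to a methoxy group weakens inhibition, with a 7.0-fold higher number from compound 3 to compound 4 (0.85 log units; beyond the scatter). Going by these compounds alone, the earlier steps altered only chains, so this is the first sign that this ring position responds to substitution, and a single chlorine atom here shifts the number further than a 2.8-fold lower number from compound 2 to compound 3 (0.44 log units; beyond the scatter) does. Nothing shown gives a reason for this shift.

The compounds shown leave open whether the loss is specific to chloro or holds for any group on this carbon. Fluoro, methyl or an amine here would separate the two.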